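The compounds below may be only part of what the source reports. "The series", "measured", "known", "first", "only" and "open" are said of these compounds alone.

Measured compounds:
Compound 1, `COc1ccc(CN(C(=O)C(C)Br)c2cc(OC)c(OC)c(OC)c2)cc1O`, with 160 nM in a functional assay on KYSE-450 cells (Homo sapiens) for inhibition, read by MTT assay, with a stated time of 48 h; on this read-out lower numbers stand for stronger inhibition and higher numbers for weaker inhibition.
Compound 2, `CCC/C=C/C(=O)N(Cc1ccc(OC)c(O)c1)c1cc(OC)c(OC)c(OC)c1`, with 57 nM in this assay.

Among the measured compounds shown here, compound 2 holds the lowest of the two numbers measured so far; its nearest neighbour is compound 1, and the step of a 2.8-fold lower number from compound 1 to compound 2 (0.45 log units; beyond the scatter) lies beyond the usual scatter. Compound 3, `CCC(=O)N(Cc1ccc(OC)c(O)c1)c1cc(OC)c(OC)c(OC)c1`, is the compound not yet measured. It differs from compound 2 by a single change: ethyl in place of pent-1-en-1-yl on a carbonyl carbon.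

For the measured compounds named here, only one measured step bears on this change, and only loosely. The step of a 2.8-fold lower number from compound 1 to compound 2 (0.45 log units; beyond the scatter) shows that exchanging the 1-bromoethyl group for the pent-1-en-1-yl group at the carbonyl carbon gave a modest but real gain. Compound 3 moves in the opposite sense, shortening the group on the carbonyl carbon to ethyl and removing the double bond outside aromatic rings. Going by the values given here, no measured pair shows ethyl directly, so the direction is uncertain; a modest rise in the number, toward that of compound 1, is the most reasonable expectation, but a result within the scatter of compound 2 cannot be excluded.

Compound 3 is therefore expected to give 120 nM in this assay, in the range 50 nM to 300 nM, a step estimated as a 2.1-fold higher number from compound 2 to compound 3 (0.32 log units; beyond the scatter).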

Compound 3, half-maximal inhibitory concentration: 98 nM
Estimate against measurement, compound 3: 1.2-fold (0.09 log units) above; low and high end bracket the measured number.
By their numbers in this assay, from the lowest: compounds 2, 3 and 1 (each within the scatter of the next, the first and the last beyond it).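

Shortening the group on the carbonyl carbon to ethyl, which also removes the double bond outside aromatic rings, is the first direct test of this position in this assay, and the pent-1-en-1-yl group proves not to be needed for a number within the scatter (a 1.7-fold higher number from compound 2 to compound 3 (0.24 log units; within the scatter)). Among the compounds shown here, the propanoyl compound also gives the first direct reading on the bromo substituent: with hydrogen in its place on the saturated chain carbon, the change again stays within the scatter (a 1.6-fold lower number from compound 1 to compound 3 (0.21 log units; within the scatter)). Compound 3 thus lies within the scatter of both neighbours, so the earlier gain seen with the combined change (a 2.8-fold lower number from compound 1 to compound 2 (0.45 log units; beyond the scatter)) cannot be assigned to either the loss of bromo or the longer unsaturated chain alone.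

Nothing shown here gives a reason for these numbers. Still open, as far as these compounds go, is whether a saturated pentyl chain would separate chain length from the double bond, and how an amine or a carboxylic acid at the end of the propanoyl chain would read in this assay.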